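Hexylsulfanyl Analogue Expected to Remain Weakly Cytotoxic

The compounds below may be only part of what the source reports. "The series", "measured", "known", "first", "only" and "open" are said of these compounds alone.

Compound 1 `CCCCSc1nc(N)nc2c1ncn2/C=C1/CC1(CO)CO` gives 89000 nM in an ADME assay on CCRF-HSB-2 cells (Homo sapiens) for cytotoxicity, with a stated time of 7 days; on this read-out lower numbers stand for higher toxicity in this test and higher numbers for lower toxicity in this test.
Compound 2 `CC(C)CNc1nc(N)nc2c1ncn2/C=C1/CC1(CO)CO` gives > 20000 nM in this assay, a limit.
Compound 3 `CCCCCOc1nc(N)nc2c1ncn2/C=C1/CC1(CO)CO` gives > 20000 nM in this assay, a limit.

Compound 3 therefore stands only at a limit in this assay, not at a number. Compound 4 `CCCCCCSc1nc(N)nc2c1ncn2/C=C1/CC1(CO)CO` differs from compound 3 by hexylsulfanyl in place of pentyloxy on an aromatic carbon. For the measured compounds named here, the steps that bear on this change are a step that the limit leaves unreadable from compound 1 to compound 3, a step that the two limits leave unreadable from compound 2 to compound 3 and a step that the limit leaves unreadable from compound 1 to compound 2, none of them readable in size, since (the limit of > 20000 nM in this assay, at which 2 of the 3 values shown sit). Only compound 1, bearing butylsulfanyl, gives a number in this assay. Compound 4 is expected to fall near that number, at an estimated 60000 nM with a range of 20000 nM to 200000 nM. The estimated step is a step that the limit leaves unreadable from compound 3 to compound 4, not readable against a limit.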

Compound 4, half-maximal cytotoxic concentration: 60000 nM
Estimate against measurement, compound 4: no gap at the digits printed; the measured number falls inside the stated range.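

In this assay, this position now carries a second number, and the two sulfanyl chains cannot be told apart: the comparison gives a 1.5-fold lower number from compound 1 to compound 4 (0.17 log units; within the scatter). Hexylsulfanyl and butylsulfanyl therefore read alike here, so the added ethyl on the chain leaves no step beyond the scatter. The steps to compound 4 from compound 2 and compound 3 cannot be read, because those two compounds stand only at limits: the limit of > 20000 nM in this assay, at which 2 of the 4 values shown sit.

The compounds shown leave open how a much longer sulfanyl chain, such as decylsulfanyl, would read at this position. They also leave open how a sulfanyl chain bearing an amine or a carboxylic acid would read.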